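The source may hold more compounds than are shown below. What is called first, only, known or untested is meant among the compounds shown, and "the series" means these compounds.

In a functional assay on NALM-6 cells (Homo sapiens) for antiproliferative activity, read by MTT assay and trypan blue exclusion, with a stated time of 72 h (a higher number here means a weaker inhibitor, a lower number a stronger inhibitor), compound 1 `COC(=O)c1ccc(C2SCC(=O)N2c2ccc(N3CCN(Cc4cccc(C)c4)CC3)cn2)c(OC)c1` gives 27300 nM. Compound 2 `COC(=O)c1ccc(C2SCC(=O)N2c2ccc(N3CCN(Cc4ccc(Cl)c(Cl)c4)CC3)cn2)c(OC)c1` reads > 100000 nM, which is a limit of the assay and not a number. Compound 2 therefore stands at the limit of > 100000 nM in this assay, at which 1 of the 2 values shown sits.

Compound 3 `COC(=O)c1ccc(C2SCC(=O)N2c2ccc(N3CCNCC3)cn2)c(OC)c1` differs from compound 2 by one change, hydrogen in place of 3,4-dichlorobenzyl on an amine nitrogen in a ring. Going by the values given here, one measured step bears on this place, an at least 3.6-fold higher number from compound 1 to compound 2 (0.56 log units; beyond the scatter), which lies beyond the scatter. That step swapped one substituent for another, so it sets no firm size for removing the group altogether. Among the compounds with values here, it does show that this assay responds to changes here, and compound 1 at 27300 nM remains the only true number nearby. A modest at least 2.5-fold lower number from compound 2 to compound 3 (0.39 log units; beyond the scatter) is therefore expected, toward a lower number. For compound 3 the estimated value is 40000 nM, with an expected range from 12000 nM to 100000 nM.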

Compound 3, half-maximal inhibitory concentration: 9710 nM
For compound 3 the middle estimate is 4.1-fold (0.61 log units) above the measured one; the measured number lies below the stated range.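

In this assay, the change to hydrogen on the amine nitrogen in the ring gives a 2.8-fold lower number from compound 1 to compound 3 (0.45 log units; beyond the scatter) and also an at least 10-fold lower number from compound 2 to compound 3 (1.01 log units; beyond the scatter). Neither the 3-methylbenzyl group nor the 3,4-dichlorobenzyl group is needed for activity at this position, and compound 3, with neither group, carries the lowest number of the three. Compound 2 gives only a limit of the assay and not a number, so its step marks a minimum size and not an exact one: the limit of > 100000 nM in this assay, at which 1 of the 3 values shown sits.

The compounds shown leave open whether a small group on this nitrogen, such as methyl or acetyl, would keep the number of compound 3 or move it. They also leave open whether an unsubstituted benzyl group would stand nearer compound 3 or compound 1.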